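This account rests on a few compounds, and the source may have more. Where it says the series, first, only, none or still open, it means among the compounds named here.

Working notes on a pair of dithiocarbamate-linked benzamides. Compound 1 `CN(Cc1cccnc1)C(=S)SCc1ccc(C(=O)Nc2ccccc2N)cc1` and compound 2 `Nc1ccccc1NC(=O)c1ccc(CSC(=S)N2CCN(c3ccncc3)CC2)cc1` were both run in a functional assay on HeLa cells (Homo sapiens) for antiproliferative activity, read by CCK-8 assay, with a stated time of 72 h, tested at 8 uM; a higher number here means a stronger effect of the compound at the concentration tested, a lower number a weaker effect. Compound 1 gives 68.7%. Compound 2 gives 77.4%, a number that lies within the usual scatter of the value for compound 1, so the two cannot be told apart on these data. Compound 3 `Nc1ccccc1NC(=O)c1ccc(CSC(=S)N2CCN(c3ncccn3)CC2)cc1` is not yet measured; it differs from compound 2 by pyrimidin-2-yl in place of pyridin-4-yl on an amine nitrogen in a ring. Within the data shown here, no measured step of this kind is available for guidance. The expectation for compound 3 is a value close to that of compound 2, with a step of a number 5.4 percentage points lower from compound 2 to compound 3 (within the scatter) that stays inside the scatter. Compound 3 is thus estimated at 72%, with a range from 55% to 88% in this assay.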

Compound 3, a percentage reported as inhibition, at one concentration (the size of the read-out at that concentration, not a potency): 73.9%
Compound 3: the middle estimate sits 1.9 percentage points below what was measured; low and high end bracket the measured number.
By their numbers in this assay, from the lowest: compounds 1, 3 and 2 (each within the scatter of the next).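

Among these compounds, the first measured step at this position, on the amine nitrogen in the ring, in this assay is a number 3.5 percentage points lower from compound 2 to compound 3 (within the scatter) and so pyrimidin-2-yl and pyridin-4-yl cannot be told apart here. Going from one to two ring hetero atoms therefore brings no readable difference in this read-out at this single concentration. No available evidence bears on this result.

Going by these compounds, whether a non-aromatic group on that nitrogen, such as cyclohexyl or acetyl, would give a similar read-out remains open. A single-concentration read-out also gives no potency for any of these compounds.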